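The source may hold more compounds than are shown below. What is called first, only, known or untested is meant among the compounds shown, and "the series" means these compounds.

Measured so far:
Compound 1 `CC(C)(C)OC(=O)Nc1ncc(C(Oc2ccc(Cc3ccccc3)cc2)c2ccc(Cl)cc2)s1` — in an ADME assay on HepG2 2.2.15 cells (Homo sapiens) for cytotoxicity (on this read-out lower numbers stand for higher toxicity in this test and higher numbers for lower toxicity in this test), compound 1 gives > 50000 nM, a limit of the test rather than a number.
Compound 2 `O=C(Nc1ncc(C(Oc2ccc3cc(Br)ccc3c2)c2ccc(Cl)cc2)s1)C1CCOCC1` — in this assay compound 2 gives "not toxic" (no number reported), a report in words without a number.

Compound 2 thus has no single number to stand on; of the two values shown, one sits at the limit of > 50000 nM in this assay, at which 1 of the 2 values shown sits. Compound 3 `O=S(=O)(Nc1ncc(C(Oc2ccc3cc(Br)ccc3c2)c2ccc(Cl)cc2)s1)c1ccc(Cl)cc1` differs from compound 2 in one place: (4-chlorophenyl)sulfonyl in place of (oxan-4-yl)carbonyl on a nitrogen on an aromatic ring. Within the data shown here, no measured step of this kind exists, so in this assay the expected change is small, at most a modest move toward higher toxicity, possibly none beyond the scatter. For compound 3 the estimated value in this assay is 30000 nM, with a range from 8000 nM to 60000 nM.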

Compound 3, half-maximal cytotoxic concentration: "not toxic" (no number reported)
For compound 3 the study gives words and no number; no gap can be computed for the estimate.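

Compound 2 and compound 3 are both reported in words alone in this assay, so no step can be read between them. The compounds shown leave open how the change from (oxan-4-yl)carbonyl to (4-chlorophenyl)sulfonyl moves this read-out in numbers.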